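This account rests on a few compounds, and the source may have more. Where it says the series, first, only, none or still open, it means among the compounds named here.

In a functional assay on NCI-H1993 cells (Homo sapiens) for cytotoxicity, read by MTT assay, with a stated time of 48 h (on this read-out lower numbers stand for stronger inhibition and higher numbers for weaker inhibition), compound 2 `COc1cc2c(Oc3ccc(NS(=O)(=O)c4cccc(-c5ccsc5)c4)cc3F)ccnc2cc1OCCCN1CCN(C)CC1` gives 1360 nM, the lowest of the two numbers shown; compound 1 `COc1cc2c(Oc3ccc(NS(=O)(=O)c4cccc(-c5cnn(C)c5)c4)cc3F)ccnc2cc1OCCCN1CCN(C)CC1` gives 6240 nM, and the step of a 4.6-fold lower number from compound 1 to compound 2 (0.66 log units; beyond the scatter) separates them. Compound 3 `COc1cc2c(Oc3ccc(NS(=O)(=O)c4cc(-c5ccsc5)ccc4F)cc3F)ccnc2cc1OCCCN1CCN(C)CC1` differs from compound 2 by fluoro in place of hydrogen on an aromatic carbon. Within the data shown here, no measured step bears on this change, since the only step at hand swaps one ring for another, so nothing in the data argues for a shift in this assay beyond the scatter. Compound 3 is therefore expected to give about 1400 nM in this assay, with a range from 500 nM to 4000 nM, which as a step means a 1.0-fold higher number from compound 2 to compound 3 (0.01 log units; within the scatter).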

Compound 3, half-maximal inhibitory concentration: 4000 nM
Compound 3: middle estimate off by 2.9-fold (0.46 log units), on the low side; measured number inside the range.
By their numbers in this assay, from the lowest: compound 2; then compounds 3 and 1 (each within the scatter of the next).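

In this assay, fluoro on the aromatic carbon ortho to a large group and para to the thiophen-3-yl group gives a 2.9-fold higher number from compound 2 to compound 3 (0.47 log units; beyond the scatter), so this position is sensitive to a single fluorine, and here the number rises. Taken together, the two changes leave a 1.6-fold lower number from compound 1 to compound 3 (0.19 log units; within the scatter), with fluoro offsetting the earlier advantage of thiophen-3-yl. Nothing available explains this shift. As far as these compounds go, whether chloro, methoxy or an amine at this position would behave likewise remains open, as does whether fluoro would have the same effect alongside 1-methyl-1H-pyrazol-4-yl.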